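Replacing 3,4-difluorophenyl with 2-hydroxyphenyl: working notes

The compounds below may be only part of what the source reports. "The series", "measured", "known", "first", "only" and "open" are said of these compounds alone.

Measured in an ADME assay on Karpas-1106P cells (Homo sapiens) for cytotoxicity; a lower number here means that less compound is needed, a higher number that more compound is needed for the effect:
- compound 1 `Cc1ccc(S(=O)(=O)N[C@@H](CC(=O)NC(C)(C)C)C(=O)NCCNC(=O)c2ccc(F)cc2)cc1`: > 11100 nM (a limit)
- compound 2 `Cc1ccc(S(=O)(=O)N[C@@H](CC(=O)NC(C)(C)C)C(=O)NCCNC(=O)c2ccc(F)c(F)c2)cc1`: > 11100 nM (a limit)

Compound 2 gives only a limit, > 11100 nM, and no number. Among the compounds with values here, the series so far shows (the limit of > 11100 nM in this assay, at which 2 of the 2 values shown sit).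

The next analogue, compound 3 `Cc1ccc(S(=O)(=O)N[C@@H](CC(=O)NC(C)(C)C)C(=O)NCCNC(=O)c2ccccc2O)cc1`, carries 2-hydroxyphenyl in place of 3,4-difluorophenyl on a carbonyl carbon.

Within the data shown here, the only measured step is a step that the two limits leave unreadable from compound 1 to compound 2. It involves fluoro in place of hydrogen on an aromatic carbon and gives no size to carry over. Among the measured compounds shown here, no measured step covers the new group, so no step beyond the scatter is expected in this assay, and no direction is favoured. The expected step is a step that the limit leaves unreadable from compound 2 to compound 3. A further limit is the likeliest report. For compound 3 the estimate is 12000 nM, with an expected range of 5000 nM to 30000 nM.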

Compound 3, half-maximal effective concentration: > 11100 nM
Compound 3 ended at the assay's limit; the forecaster's own chance of this, stated with the estimate: 85%; the middle value is on the limit's open side.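

No new step can be read for compound 3 against compound 1 or compound 2, as each value is a limit and not a number: the limit of > 11100 nM in this assay, at which 3 of the 3 values shown sit.

The compounds shown leave open how far any of the three lies past that limit, and whether 2-hydroxyphenyl and 3,4-difluorophenyl differ at all in this assay.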